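Hydroxy to Hydrogen on the Aryl Ring: Expected Shift

The source may report more compounds than this note shows. Statements on the series, on what has been measured and on what is new or still open speak of the compounds shown alone.

Compound 1 `COC(=O)N1N=C(c2ccccc2)CC1c1cc(OC)c(OC)c(OC)c1`, compound 2 `COC(=O)N1N=C(c2cccc(O)c2)CC1c1cc(OC)c(OC)c(OC)c1` and compound 3 `COC(=O)N1N=C(c2ccccc2)CC1c1ccc(OC)c(O)c1` share a core. In a functional assay on A549 cells (Homo sapiens) for antiproliferative activity, read by MTT assay, with a stated time of 48 h (on this read-out higher numbers stand for weaker inhibition of growth and lower numbers for stronger inhibition of growth), compound 1 gives 2880 nM, compound 2 gives 3170 nM, and compound 3 gives 8930 nM. The difference between the cores of compound 3 and compound 2 is not broken down here. From compound 2 to compound 1 the change is hydrogen in place of hydroxy on an aromatic carbon, and the step was a 1.1-fold lower number from compound 2 to compound 1 (0.04 log units; within the scatter). Compound 4 `COC(=O)N1N=C(c2ccccc2)CC1c1ccc(OC)cc1` differs from compound 3 by hydrogen in place of hydroxy on an aromatic carbon. The place is not identical: in compound 3 the hydroxy is ortho to a methoxy group, while in compound 2 it is only meta to a large group, so this is the same kind of change, not the same. Compound 4 is expected to show a step of a 1.0-fold higher number from compound 3 to compound 4 (0.00 log units; within the scatter), resting on the earlier step of a 1.1-fold lower number from compound 2 to compound 1 (0.04 log units; within the scatter). Compound 4 is thus estimated at 9000 nM.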

Compound 4, concentration for 50% growth inhibition: 15300 nM
Beside the measured number, compound 4's estimate is 1.7-fold (0.23 log units) below it; the measured number falls inside the stated range.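

In this assay, hydrogen in place of hydroxy gave a 1.7-fold higher number from compound 3 to compound 4 (0.23 log units; within the scatter) on the core of compound 3. Set beside the earlier step, the same change shows no difference between the two cores that can be told from scatter: the same change on two cores in this assay, a 1.1-fold lower number (0.04 log units; within the scatter) from compound 2 to compound 1 and a 1.7-fold higher number (0.23 log units; within the scatter) from compound 3 to compound 4, 1.9-fold (0.28 log units) apart, within the scatter of two such steps. Among these compounds, this shows that the step stayed small on both pairs, but it rests on only two pairs, with the hydroxy in a different place on each, and it does not show that the step would hold on other cores.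

The compounds shown leave open whether an amine or a carboxylic acid in the place of the hydroxy would give a similarly small step. They also leave open whether a fluorine there would do so.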